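The source may report more compounds than this note shows. Statements on the series, on what has been measured and on what is new or still open speak of the compounds shown alone.

Three members of the series have numbers in an assay on MDA-MB-231 cells for displacement of a labelled ligand from C-X-C chemokine receptor type 4 (Homo sapiens), read by fluorescence and microscopy, with stated times of 10 min and 30 min; a lower number here means that less compound is needed, a higher number that more compound is needed for the effect. Compound 1 `COc1ccccc1C(=O)NCc1ccc(CNS(=O)(=O)c2cccc(F)c2)cc1` gives 1000 nM, compound 2 `Cc1cccc(S(=O)(=O)NCc2ccc(CNC(=O)c3ccccc3C)cc2)c1` gives 1000 nM, and compound 3 `Cc1ccccc1C(=O)NCc1ccc(CNS(=O)(=O)c2cccc(Cl)c2)cc1` gives 100 nM, the lowest of the three, with compound 1 and compound 2 each a step beyond the scatter away as shown by their values. Within the data shown here, the one single-point step recorded, a 10-fold lower number from compound 2 to compound 3 (1.00 log units; beyond the scatter), concerns a different exchange. Compound 4 `Cc1ccccc1C(=O)NCc1ccc(CNS(=O)(=O)c2cccc(F)c2)cc1` differs from compound 3 as follows: fluoro in place of chloro on an aromatic carbon. Among the measured compounds shown here, no measured step covers this halogen exchange directly; compound 1, which carries the fluoro but also a methoxy instead of methyl, sits at 1000 nM against compound 3 at 100 nM, which hints that a higher number is plausible. A modest rise, a 3.0-fold higher number from compound 3 to compound 4 (0.48 log units; beyond the scatter), is therefore expected. Compound 4 is estimated at 300 nM, within 100 nM to 1000 nM.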

Compound 4, effective concentration (reported as EC, without a stated level of effect): 100 nM
For compound 4 the middle estimate is 3.0-fold (0.48 log units) above the measured one; the measured number falls inside the stated range.
By their numbers in this assay, from the lowest: compounds 3 and 4 (each within the scatter of the next); then compounds 1 and 2 (each within the scatter of the next).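

In this assay, the exchange of 3-chlorophenyl for 3-fluorophenyl can now be read directly, and the two halogens are indistinguishable here (no change at the digits printed from compound 3 to compound 4 (within the scatter)). Fluoro in place of methyl at this position gives a step beyond the scatter (a 10-fold lower number from compound 2 to compound 4 (1.00 log units; beyond the scatter)), and so does methyl in place of methoxy on the other side of the molecule (a 10-fold lower number from compound 1 to compound 4 (1.00 log units; beyond the scatter)), which ties the higher value of compound 1 to the methoxy and not to the fluoro. No measurement at hand explains these steps.

Going by these compounds, whether an amine, a carboxylic acid or a longer chain at this position would hold the number stays open. So does the outcome of placing fluoro on another aromatic carbon.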